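Ethyl to Methoxy on the Shared Core

The source may report more compounds than this note shows. Statements on the series, on what has been measured and on what is new or still open speak of the compounds shown alone.

Compound 1 `CCc1cccc2c(=O)c(-c3nn[nH]n3)c[nH]c12` gives 0.312 mg/kg in a functional assay on the whole organism (strain Sprague-Dawley) for inhibition, with Rattus norvegicus as the target (a lower number here means that less compound is needed, a higher number that more compound is needed for the effect), the lowest of the two numbers recorded. Compound 3 `Cc1ccc2cc(C(=O)O)cnc2c1C`, a different core, gives 25 mg/kg in this assay, a far higher number, well beyond the usual scatter. Compound 2 `O=c1c(-c2nn[nH]n2)c[nH]c2ccc(Cl)cc12` reaches only a limit of this assay, > 10 mg/kg; one of the three recorded values sits at the limit of > 10 mg/kg in this assay, at which 1 of the 3 values shown sits.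

Compound 4 `COc1cccc2c(=O)c(-c3nn[nH]n3)c[nH]c12` differs from compound 1 in a single place: methoxy in place of ethyl on an aromatic carbon. Going by the values given here, no measured pair covers this change, so its size is unknown from the data. Compound 4 is expected to show a modest step, a 1.9-fold higher number from compound 1 to compound 4 (0.28 log units; within the scatter), toward a somewhat higher number, still within or near the scatter. Compound 4 is estimated at 0.6 mg/kg, with a range from 0.15 mg/kg to 3 mg/kg.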

Compound 4, minimum effective dose: 0.15 mg/kg
Estimate against measurement, compound 4: 4.0-fold (0.60 log units) above, and the stated range covers the measured number.
By their numbers in this assay, from the lowest: compound 4; then compound 1; then compound 3.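

Methoxy in place of ethyl on this aromatic carbon of the shared core gives a 2.1-fold lower number from compound 1 to compound 4 (0.32 log units; beyond the scatter) in this assay and is the first single-place step in the set. The position therefore accepts a group carrying a hydrogen-bond acceptor with no loss, and ethyl is not required there for a low dose. Nothing recorded here accounts for the step.

From the compounds shown here alone, whether an amine, a hydroxyl or a longer chain such as ethoxy would go lower at this position stays open. A single step also cannot say whether methoxy would do the same elsewhere on the core.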